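This account rests on a few compounds, and the source may have more. Where it says the series, first, only, none or still open, it means among the compounds named here.

In a functional assay on MCF7 cells (Homo sapiens) for cytotoxicity, read by sulforhodamine B assay (on this read-out lower numbers stand for higher toxicity in this test and higher numbers for lower toxicity in this test), compound 1 `CC1=CC[C@@H]([C@@](C)(O)CCCC(C)(C)NC(=S)N/N=C\c2ccc(C)cc2)CC1` reaches only a limit, > 100000 nM. Among the measured compounds shown here, compound 2 `CC1=CC[C@@H]([C@@](C)(O)CCCC(C)(C)NC(=S)N/N=C\c2ccc(O)cc2)CC1` gives 56400 nM, the only true number so far, so it has no measured value to be ranked against. Compound 3 `CC1=CC[C@@H]([C@@](C)(O)CCCC(C)(C)NC(=S)N/N=C\c2cccc([N+](=O)[O-])c2)CC1` carries 3-nitrophenyl in place of 4-hydroxyphenyl on a carbon with a double bond to nitrogen. The hydroxy group of compound 2 is therefore lost again, and a single measured step bears on that loss: an at least 1.7-fold lower number from compound 1 to compound 2 (0.24 log units; that floor lies within the scatter). That step swapped hydroxy for methyl on an aromatic carbon, and it is known only as a floor, so it sets no firm size. At most a small move toward a higher number is expected, with nothing clearly beyond the scatter, as an estimated 1.2-fold higher number from compound 2 to compound 3 (0.09 log units; within the scatter). For compound 3 the expected value is 70000 nM, within an estimated range of 25000 nM to 130000 nM.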

Compound 3, concentration lethal to 50% of the cells: 47300 nM
Beside the measured number, compound 3's estimate is 1.5-fold (0.17 log units) above it; low and high end bracket the measured number.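

In this assay, the 4-hydroxyphenyl group on a carbon with a double bond to nitrogen gives way to 3-nitrophenyl with a 1.2-fold lower number from compound 2 to compound 3 (0.08 log units; within the scatter), so the hydroxy group of compound 2 is not needed to hold the number at this level. Compound 1 gives > 100000 nM, which is a limit of the assay and not a number. Even so, an at least 2.1-fold lower number from compound 1 to compound 3 (0.32 log units; beyond the scatter) gives the first comparison at this position that clears the scatter, though it fixes only a floor, with the true size unknown.

The step from compound 2 to compound 3 changes both the group and where it sits on the ring, so the two changes cannot be told apart, and 4-nitrophenyl would separate them. As far as these compounds go, how an amine or a carboxylic acid on this ring would read remains open.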